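Sulfonyl substituent change on the shared core

This account rests on a few compounds, and the source may have more. Where it says the series, first, only, none or still open, it means among the compounds named here.

Measured so far:
compound 1 `CC(C)c1noc(N2CCN(C(=O)[C@@H]3CCCN(S(=O)(=O)c4ccc(S(=O)(=O)C(C)C)cc4)C3)CC2)n1` gives 70 nM
compound 2 `CC(C)c1noc(N2CCN(C(=O)[C@@H]3CCCN(S(=O)(=O)c4ccc(S(=O)(=O)NC5CCC5)cc4)C3)CC2)n1` gives 600 nM

In a functional assay on MIA PaCa-2 cells (Homo sapiens) for inhibition, read by MTT assay, with a stated time of 7 days (a lower number here means a stronger inhibitor, a higher number a weaker inhibitor), compound 2 stands at the higher of the two numbers recorded. Within the data shown here, the only step within the measured pair, from compound 1 to compound 2, reads an 8.6-fold higher number from compound 1 to compound 2 (0.93 log units; beyond the scatter). Compound 3 `CCC(CC)S(=O)(=O)c1ccc(S(=O)(=O)N2CCC[C@@H](C(=O)N3CCN(c4nc(C(C)C)no4)CC3)C2)cc1` differs from compound 2 by pentan-3-yl in place of cyclobutylamino on a sulfonyl sulfur. Among the measured compounds shown here, the single measured step bears on this directly: it is the step that brought the cyclobutylamino group onto the sulfonyl sulfur, and compound 3 removes it again in favour of a carbon substituent, as in compound 1. A move back of roughly that size is therefore expected, and the step is estimated as a 6.0-fold lower number from compound 2 to compound 3 (0.78 log units; beyond the scatter). Compound 3 is expected to give 100 nM, with a range of 35 nM to 300 nM, since the pentan-3-yl group is a somewhat larger carbon substituent than the isopropyl of compound 1.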

Compound 3, half-maximal inhibitory concentration: 50 nM
Compound 3: middle estimate off by 2.0-fold (0.30 log units), on the high side; the range from low to high includes it.
By their numbers in this assay, from the lowest: compounds 3 and 1 (each within the scatter of the next); then compound 2.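

In this assay, pentan-3-yl on the sulfonyl sulfur gives a 12-fold lower number from compound 2 to compound 3 (1.08 log units; beyond the scatter), so the loss seen with cyclobutylamino is not confined to a return to isopropyl: a second carbon substituent also reverses it. Pentan-3-yl in place of isopropyl gives a 1.4-fold lower number from compound 1 to compound 3 (0.15 log units; within the scatter), so these two carbon substituents cannot be told apart at this position. No measurement on hand accounts for the gap between them and cyclobutylamino.

From the compounds shown here alone, whether the higher number of compound 2 goes with the nitrogen, its hydrogen or the four-membered ring stays open; dimethylamino and cyclobutyl on the same sulfur would separate these features. Going by these compounds, how far the carbon substituent can change before the number moves also stays open, for instance with cyclohexyl or a longer unbranched chain.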